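Amide Substituent Variation on the Shared Core

The source may report more compounds than this note shows. Statements on the series, on what has been measured and on what is new or still open speak of the compounds shown alone.

Compound 2 `Nc1sc(-c2ccc(Cl)cc2)c(-c2ccc(Cl)cc2)c1C(=O)NC1CCCCC1` gives 2410 nM in a functional assay on A549 cells (Homo sapiens) for inhibition, read by sulforhodamine B assay, with a stated time of 72 h (a higher number here means a weaker inhibitor, a lower number a stronger inhibitor), and stands second highest of the three numbers measured. Compound 1 `Nc1sc(-c2ccc(Cl)cc2)c(-c2ccc(Cl)cc2)c1C(=O)N1CCCCC1` gives 4620 nM and compound 3 `CN1CCN(C(=O)c2c(N)sc(-c3ccc(Cl)cc3)c2-c2ccc(Cl)cc2)CC1` gives 590 nM. The change from compound 2 to compound 4 `Nc1sc(-c2ccc(Cl)cc2)c(-c2ccc(Cl)cc2)c1C(=O)NCc1ccccc1` is benzyl in place of cyclohexyl on an amide-type nitrogen. Two measured steps alter the same carbonyl substituent and bear on it: a 1.9-fold lower number from compound 1 to compound 2 (0.28 log units; within the scatter), and a 4.1-fold lower number from compound 2 to compound 3 (0.61 log units; beyond the scatter). Going by the values given here, neither involves a benzyl group, and the only step beyond the scatter brought in the 4-methylpiperazin-1-yl group, which compound 4 lacks. A step of at most modest size, direction uncertain, is therefore expected: a 1.2-fold lower number from compound 2 to compound 4 (0.08 log units; within the scatter). Compound 4 is estimated at 2000 nM, within the range 700 nM to 6000 nM.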

Compound 4, half-maximal inhibitory concentration: 16300 nM
Compound 4: middle estimate off by 8.2-fold (0.91 log units), on the low side, outside the stated range (above it).
By their numbers in this assay, from the lowest: compound 3; then compounds 2 and 1 (each within the scatter of the next); then compound 4.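

In this assay, benzyl in place of cyclohexyl on the amide-type nitrogen gives a 6.8-fold higher number from compound 2 to compound 4 (0.83 log units; beyond the scatter), so this position responds to a swap between two carbon-only groups with no hydrogen-bond donors, acceptors or net charge. Compound 4 also stands apart from the other two amides (a 3.5-fold higher number from compound 1 to compound 4 (0.55 log units; beyond the scatter); a 28-fold higher number from compound 3 to compound 4 (1.44 log units; beyond the scatter)), which makes it the weakest inhibitor of the four. No measurement shown accounts for this rise. Still open, on these data alone, is whether the aromatic ring or its methylene link drives the change; a phenyl group on the amide nitrogen or a longer phenylethyl chain would separate the two.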